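The source may report more compounds than this note shows. Statements on the series, on what has been measured and on what is new or still open speak of the compounds shown alone.

Of the compounds shown here, three that share one core have been measured in an ADME assay on liver for metabolic stability, with Liver microsome (Homo sapiens) as the target, read by LC-MS, using microsomes; on this read-out higher numbers stand for fast clearance and lower numbers for slow clearance. Compound 1, `CC(C)(C)[C@@H](O)C(=O)N1CSC[C@H]1C(=O)NCc1cc(Cl)ccc1-n1cnnn1`, gives 120 mL.min-1.g-1 in this assay. Compound 2, `O=C(NCc1cc(Cl)ccc1-n1cnnn1)[C@@H]1[C@H]2C[C@H]2CN1C(=O)[C@H](O)CC1CC1`, returns in this assay only a limit of the assay, < 14 mL.min-1.g-1, so for compound 2 the clearance is known as a bound and not as a number (the limit of < 14 mL.min-1.g-1 in this assay, at which 1 of the 3 values shown sits). Compound 3, `Cc1cccc([C@@H](O)C(=O)N2N=CC[C@H]2C(=O)NCc2cc(Cl)ccc2-n2cnnn2)c1`, also returns in this assay only a limit of the assay, < 12 mL.min-1.g-1 (the limit of < 12 mL.min-1.g-1 in this assay, at which 1 of the 3 values shown sits). Among the three values shown, then, compound 2 sits at one of the two limits, at the slow end of what the assay reports, while the one numerical value belongs to compound 1.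

Compound 4, `O=C(NCc1cc(Cl)ccc1-n1cnnn1)[C@@H]1[C@H]2C[C@H]2CN1C(=O)[C@H](O)c1ccccc1`, has not been measured. It differs from compound 2 in a single place: phenyl in place of cyclopropylmethyl on a saturated chain carbon bound to a carbonyl carbon and an oxygen on a saturated carbon. Among the compounds with values here, no pair of measured compounds differs in just one spot, so the size of this kind of step has not been seen here. Compound 4 is expected to stay near the slow end, because compound 2 reports < 14 mL.min-1.g-1 in this assay and the change is confined to one substituent. The expected step of an at least 1.0-fold higher number from compound 2 to compound 4 (0.02 log units; that floor lies within the scatter) is small, within the usual scatter. Compound 4 is therefore estimated at 15 mL.min-1.g-1 in this assay, with a range from 7 mL.min-1.g-1 to 40 mL.min-1.g-1.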

Compound 4, intrinsic clearance in microsomes: 61 mL.min-1.g-1
Beside the measured number, compound 4's estimate is 4.1-fold (0.61 log units) below it, outside the stated range (above it).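

In this assay, within the data shown here, the place on a saturated chain carbon bound to a carbonyl carbon and an oxygen now proves able to change the read-out: phenyl in place of cyclopropylmethyl gives an at least 4.3-fold higher number from compound 2 to compound 4 (0.63 log units; beyond the scatter), the first step in this set that changes only one place. This size is a floor and not an exact figure, since compound 2 gives only a limit of the assay: the limit of < 14 mL.min-1.g-1 in this assay, at which 1 of the 4 values shown sits. Compound 4 keeps everything else from compound 2. Compound 4 gives 61 mL.min-1.g-1 as a numerical value, so a change at this one place is enough to give faster clearance.

The two groups differ both in their count of heavy atoms and in that phenyl is an aromatic ring while cyclopropylmethyl holds a three-membered non-aromatic one, so this single step cannot separate these differences from each other. Still open, on these data alone, is where cyclohexyl, a six-membered ring of carbon that is not aromatic, would fall at this place, and whether the same swap would give a step of similar size on another core.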